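The source may report more compounds than this note shows. Statements on the series, on what has been measured and on what is new or still open speak of the compounds shown alone.

In a functional assay on A549 cells (Homo sapiens) for inhibition, read by MTT assay, with a stated time of 72 h (on this read-out lower numbers stand for stronger inhibition and higher numbers for weaker inhibition), compound 1 `Clc1ccc(-c2nnc(SCCCN3CCN(c4nc5ccccc5o4)CC3)o2)cc1` gives 127000 nM and so stands within the scatter of compound 2 `Brc1ccc(-c2nnc(SCCCN3CCN(c4nc5ccccc5o4)CC3)o2)cc1` at 123000 nM and of compound 3 `O=C(NCc1nnc(SCCCN2CCN(c3nc4ccccc4o3)CC2)o1)c1ccccc1` at 102000 nM as well. Compound 4 `Clc1ccc(-c2nnc(SCCCN3CCN(c4nc5ccccc5s4)CC3)o2)cc1` exchanges one group of compound 1 (1,3-benzothiazol-2-yl in place of 1,3-benzoxazol-2-yl on an amine nitrogen in a ring) and keeps the rest. The measured steps, namely a 1.0-fold lower number from compound 1 to compound 2 (0.01 log units; within the scatter) and a 1.2-fold lower number from compound 1 to compound 3 (0.10 log units; within the scatter) and a 1.2-fold lower number from compound 2 to compound 3 (0.08 log units; within the scatter) all lie within the scatter, yet none of them alters that group, so they offer only an indirect guide. In this assay no change beyond the scatter is expected for compound 4, an estimated step (a 1.2-fold lower number from compound 1 to compound 4 (0.06 log units; within the scatter)) that stays small. Compound 4 is estimated at 110000 nM with a likely range from 50000 nM to 240000 nM in this read-out.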

Compound 4, half-maximal inhibitory concentration: 110000 nM
Beside the measured number, compound 4's estimate shows no gap at the digits printed; low and high end bracket the measured number.
By their numbers in this assay, from the lowest: compounds 3, 4, 2 and 1 (each within the scatter of the next).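

Putting 1,3-benzothiazol-2-yl in place of 1,3-benzoxazol-2-yl on the amine nitrogen in a ring gives, in this assay, a 1.2-fold lower number from compound 1 to compound 4 (0.06 log units; within the scatter). Among these compounds, this is the first direct test of this position, since the earlier steps left this group untouched, and it shows that exchanging oxygen for sulfur in this group leaves the number within the scatter. No measurement at hand explains this result. As far as these compounds go, it remains open whether a different kind of group on this nitrogen, such as a plain phenyl or an acetyl, would move the number beyond the scatter.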